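Halogen swap on the terminal phenyl urea

The source may report more compounds than this note shows. Statements on the series, on what has been measured and on what is new or still open speak of the compounds shown alone.

Measured compounds:
compound 1 `CN(C)CCCNc1nc(-c2ccc(NC(=O)Nc3ccc(Cl)cc3)cc2)nc2c(Cl)c(Cl)sc12` with 230 nM
compound 2 `CN(C)CCNc1nc(-c2ccc(NC(=O)Nc3ccc(F)cc3)cc2)nc2c(Cl)c(Cl)sc12` with 590 nM

In a functional assay on NCI-H460 cells (Homo sapiens) for cytotoxicity, read by MTT assay, with a stated time of 72 h (a lower number here means a stronger inhibitor, a higher number a weaker inhibitor), compound 2 gives the higher of the two numbers; compound 1 gives a number beyond the scatter below it, and the two differ in two places at once, so no single step can be read from them. Compound 3 `CN(C)CCNc1nc(-c2ccc(NC(=O)Nc3ccc(Cl)cc3)cc2)nc2c(Cl)c(Cl)sc12` keeps the two-carbon chain of compound 2 and carries chloro in place of fluoro on an aromatic carbon, chloro in place of fluoro on an aromatic carbon, para to a large group. With no measured step of this kind in the series, a small move from compound 2 toward compound 1 is expected, a 1.6-fold lower number from compound 2 to compound 3 (0.19 log units; within the scatter), near the edge of the scatter. Compound 3 is estimated at 380 nM, range 160 nM to 900 nM.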

Compound 3, half-maximal inhibitory concentration: 300 nM
Beside the measured number, compound 3's estimate is 1.3-fold (0.10 log units) above it, within the range that was stated.
By their numbers in this assay, from the lowest: compounds 1, 3 and 2 (each within the scatter of the next, the first and the last beyond it).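

In this assay, chloro in place of fluoro on the aromatic carbon para to a large group can now be read alone (a 2.0-fold lower number from compound 2 to compound 3 (0.29 log units; within the scatter)); so can the chain change, dimethylamino in place of (dimethylamino)methyl (a 1.3-fold higher number from compound 1 to compound 3 (0.12 log units; within the scatter)). Both steps stay within the scatter, so neither change alone accounts for the gap beyond the scatter between compound 1 and compound 2. No measurement bears on a cause for these steps.

Still open, on these data alone, are a bromo group at this aromatic carbon and a longer chain carrying the dimethylamino group. As far as these compounds go, a morpholine in place of dimethylamino is also open.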